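This account rests on a few compounds, and the source may have more. Where it says the series, first, only, none or still open, it means among the compounds named here.

Measured in a functional assay on KB403 cells (Homo sapiens) for cytotoxicity, read by MTT assay, with stated times of 6 h and 48 h; on this read-out higher numbers stand for weaker inhibition and lower numbers for stronger inhibition:
- Compound 1 `Cn1c(/C=C/C(=O)c2ccccc2O)cc(Br)c1Br`: 8320 nM
- Compound 2 `Cn1c(/C=C/C(=O)c2ccccc2)cc(Br)c1Br`: >= 100000 nM (a limit)
- Compound 3 `O=C(/C=C/c1cc(Br)c(Br)[nH]1)c1ccccc1O`: >= 100000 nM (a limit)

Compound 3 has no exact number and is known only through (the limit of >= 100000 nM in this assay, at which 2 of the 3 values shown sit). Compound 4 `O=C(/C=C/c1cc(Br)c(Br)[nH]1)c1ccccc1` differs from it by one change: hydrogen in place of hydroxy on an aromatic carbon. The same swap has been measured once, and it gave an at least 12-fold higher number from compound 1 to compound 2 (1.07 log units; beyond the scatter). The other measured step, a different change, gave an at least 12-fold higher number from compound 1 to compound 3 (1.07 log units; beyond the scatter), which is how the series reached this limit. Both steps are large, and the first points towards weaker inhibition. A further loss would therefore be expected, but it could hardly show in this assay, so the number is expected to stay near the limit. The expected change is a number no higher from compound 3 to compound 4 (the limit leaves the size open). Compound 4 is estimated at 100000 nM. For compound 4 the expected range runs from 60000 nM to 200000 nM.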

Compound 4, half-maximal inhibitory concentration: >= 100000 nM
Compound 4: no number, only a limit; the forecaster's own chance of this, stated with the estimate: 85%; the middle value lies on the limit itself.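

Compound 2, compound 3 and compound 4 each give only a limit, so no step to compound 4 can be read: the limit of >= 100000 nM in this assay, at which 3 of the 4 values shown sit.

Going by these compounds, how weak these three compounds really are stays open, as does whether removing the hydroxy changes anything in compound 3.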